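Extending the acid side chain of an antagonist series

This account rests on a few compounds, and the source may have more. Where it says the series, first, only, none or still open, it means among the compounds named here.

Compound 1, with the structure `CC(C(=O)O)c1nn(Cc2cn3cc(OCC4CC4)c(Cl)cc3n2)c2ccccc2c1=O`, is the reference point in a functional assay on CHO cells for antagonist activity at sphingosine 1-phosphate receptor 2 (Homo sapiens), read by GTPgammaS binding; a lower number here means a stronger inhibitor, a higher number a weaker inhibitor. In this assay compound 1 gives 31 nM, the lowest of the two numbers recorded so far. For the measured compounds named here, its only measured neighbour is compound 2, `CC(C(=O)O)c1nn(Cc2cn3cc(OCC4CC4)c(C(F)(F)F)cc3n2)c2ccccc2c1=O`, which in this assay gives 51 nM; the step of a 1.6-fold higher number from compound 1 to compound 2 (0.22 log units; within the scatter) is the one comparison available, and it concerns an exchange on the aromatic ring, not the acid-bearing chain.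

Compound 3, `CCC(C(=O)O)c1nn(Cc2cn3cc(OCC4CC4)c(Cl)cc3n2)c2ccccc2c1=O`, is not yet measured. It differs from compound 1 by methyl in place of hydrogen on a saturated chain carbon, two bonds along the chain from an aromatic carbon and a carbonyl carbon. Going by the values given here, no measured pair in this set covers a change at that position, so the step from compound 1 to compound 2 does not speak to it directly; it shows only that one small exchange elsewhere in the molecule left the number within the scatter.

With nothing pointing either way, compound 3 is expected to sit close to compound 1, with the step of a 1.3-fold higher number from compound 1 to compound 3 (0.11 log units; within the scatter) estimated to stay inside the scatter. The estimate for compound 3 in this assay is 40 nM, with a range from 15 nM to 120 nM.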

Compound 3, half-maximal inhibitory concentration: 43 nM
Estimate against measurement, compound 3: 1.1-fold (0.03 log units) below; low and high end bracket the measured number.
By their numbers in this assay, from the lowest: compounds 1, 3 and 2 (each within the scatter of the next).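

In this assay, the change from 1-carboxyethyl to 1-carboxypropyl, which is methyl in place of hydrogen on a saturated chain carbon, gives a 1.4-fold higher number from compound 1 to compound 3 (0.14 log units; within the scatter), so this one added carbon does not move the number beyond the usual scatter. For the compounds shown here, the earlier comparison concerned only an exchange on the aromatic ring, so this is the first measured reading from the acid-bearing chain itself, and it shows that this chain can carry an extra methyl without a clear loss or gain in inhibition. Nothing available here explains why the added carbon makes so little difference.

Going by these compounds, one added methyl is only a single point, so it stays open whether a longer chain such as propyl, a branched group such as isopropyl, or a hydroxyl group at this same carbon would also leave the number inside the scatter. Going by these compounds alone, also open is whether the same methyl would give a similar result on the trifluoromethyl-bearing compound 2, where this change has no measured counterpart.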